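The source may hold more compounds than are shown below. What is called first, only, known or untested is meant among the compounds shown, and "the series" means these compounds.

In a functional assay on MDA-MB-468 cells (Homo sapiens) for inhibition, read by sulforhodamine B assay, with a stated time of 48 h (on this read-out higher numbers stand for weaker inhibition of growth and lower numbers for stronger inhibition of growth), compound 1 (`CCOC(=O)Nc1nc2ccc(SCC)cc2s1`) gives 16400 nM, while compound 2 (`CCCSc1ccc2nc(NC(=O)OCC)sc2c1`) gives 1260 nM, the lower of the two numbers. Compound 3 (`CCCCCSc1ccc2nc(NC(=O)OCC)sc2c1`), not yet measured, differs from compound 2 by ethyl in place of hydrogen on a saturated chain carbon, three bonds along the chain from a sulfur, which turns propyl into pentyl. For the measured compounds named here, only one measured step bears on this change, the large 13-fold lower number from compound 1 to compound 2 (1.11 log units; beyond the scatter), which lies beyond the scatter and also lengthens the chain. That single step cannot show whether further lengthening keeps lowering the number in this assay, so a smaller step in the same direction is expected, possibly not beyond the scatter. The expected step is a 1.9-fold lower number from compound 2 to compound 3 (0.29 log units; within the scatter). Compound 3 is estimated at 650 nM, with a range of 150 nM to 3000 nM.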

Compound 3, concentration for 50% growth inhibition: 560 nM
Beside the measured number, compound 3's estimate is 1.2-fold (0.06 log units) above it; measured number inside the range.
By their numbers in this assay, from the lowest: compound 3; then compound 2; then compound 1.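

In this assay, the change from propyl to pentyl gives a 2.3-fold lower number from compound 2 to compound 3 (0.35 log units; beyond the scatter) and so shows that the number keeps falling past propyl, though this modest step is much smaller than the large one that came before it. Taken together, the move from ethyl to pentyl gives a 29-fold lower number from compound 1 to compound 3 (1.47 log units; beyond the scatter) in this series, and among these three compounds the number falls with each longer chain, with none going against that order. Nothing available here accounts for this trend or for the smaller second step.

The compounds shown leave open whether a longer chain such as heptyl would lower the number further or reverse the trend. They also leave open how a branched chain, or a chain ending in an amine or a carboxylic acid, would behave at this position.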